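From pyridin-2-yl to 1-methyl-1H-pyrazol-4-yl on the core

A few compounds are considered here, and "the series" means these few. Any claim that something is new, unique, unknown or untested is made for them only; others in the source may bear on it.

Compound 2 `Cc1cc(C)c(NC(=O)N(Cc2ccc(-c3ccccn3)cc2)C2CCCCCC2)c(C)c1` gives 33 nM in an assay on microsomes from intestine for inhibition of acyl-CoA:cholesterol acyltransferase (Oryctolagus cuniculus) (a higher number here means a weaker inhibitor, a lower number a stronger inhibitor), and stands alongside compound 1 `O=C(Nc1c(F)cc(F)cc1F)N(Cc1ccc(-c2ccccn2)cc1)C1CCCCCC1`, which gives 25 nM; the step of a 1.3-fold higher number from compound 1 to compound 2 (0.12 log units; within the scatter) lies within the scatter. Compound 3 `Cc1cc(C)c(NC(=O)N(Cc2ccc(-c3cnn(C)c3)cc2)C2CCCCCC2)c(C)c1` differs from compound 2 by 1-methyl-1H-pyrazol-4-yl in place of pyridin-2-yl on an aromatic carbon. For the measured compounds named here, no measured step touches this part of the molecule: the only step known changes the group on the amide-type nitrogen and says nothing about the aryl end. Compound 3 is therefore expected near compound 2, with a wide range, at 60 nM between 15 nM and 250 nM. The expected step is a 1.8-fold higher number from compound 2 to compound 3 (0.26 log units; within the scatter).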

Compound 3, half-maximal inhibitory concentration: 47 nM
Compound 3: middle estimate off by 1.3-fold (0.11 log units), on the high side, within the range that was stated.
By their numbers in this assay, from the lowest: compounds 1, 2 and 3 (each within the scatter of the next).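

In this assay, for the compounds shown here, the first change at this aryl end, 1-methyl-1H-pyrazol-4-yl in place of pyridin-2-yl, gives a 1.4-fold higher number from compound 2 to compound 3 (0.15 log units; within the scatter) and so cannot be told apart from no effect. A five-membered aromatic ring with 2 hetero atoms therefore reads the same here as a six-membered aromatic ring with 1 hetero atom, at least for this pair. Nothing available explains this result. Still open, on these data alone, is whether a carboxylic acid or an amine at this position would hold the number equally well. Also open, as far as these compounds go, is whether 1-methyl-1H-pyrazol-4-yl behaves the same alongside 2,4,6-trifluorophenyl.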